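Fluoro added to the amide aryl ring of compound 1

The source may report more compounds than this note shows. Statements on the series, on what has been measured and on what is new or still open speak of the compounds shown alone.

Compound 1 `O=C(Nc1ccc(Oc2ccnc3[nH]ccc23)cc1)c1cc2cccnc2n(-c2ccc(Cl)cc2)c1=O` is the reference of the set. In a functional assay on A549 cells (Homo sapiens) for antiproliferative activity, read by MTT assay, with a stated time of 72 h (on this read-out lower numbers stand for stronger inhibition and higher numbers for weaker inhibition), compound 1 gives 290 nM, the lowest number among the three measured compounds. Compound 2 `COc1ccc(-n2c(=O)c(C(=O)Nc3ccc(Oc4ccnc5[nH]ccc45)cc3)cc3cccnc32)cc1` gives 930 nM in this assay, which is a 3.2-fold higher number from compound 1 to compound 2 (0.51 log units; beyond the scatter). Compound 3 `O=C(Nc1ccc(Oc2ccnc3[nH]ccc23)cc1)c1cc2cccnc2n(-c2ccc(C(F)(F)F)cc2Cl)c1=O` gives 3230 nM in this assay, so that an 11-fold higher number from compound 1 to compound 3 (1.05 log units; beyond the scatter) and a 3.5-fold higher number from compound 2 to compound 3 (0.54 log units; beyond the scatter). Both measured steps alter only the aryl group on the aromatic nitrogen of the shared core; the amide-bearing ring is the same in all three.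

Compound 4 `O=C(Nc1ccc(Oc2ccnc3[nH]ccc23)c(F)c1)c1cc2cccnc2n(-c2ccc(Cl)cc2)c1=O` differs from compound 1 at that other ring: fluoro in place of hydrogen on an aromatic carbon. Among the compounds with values here, none of the measured steps bears on this position, so the set gives no direct precedent for the change. Within the data shown here, with no measured step on this ring to draw on, the expectation for compound 4 in this assay is a number close to that of compound 1, the estimated step being a 1.0-fold higher number from compound 1 to compound 4 (0.01 log units; within the scatter). For compound 4 the estimate in this assay is 300 nM, expected to lie within 120 nM to 750 nM.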

Compound 4, half-maximal inhibitory concentration: 110 nM
For compound 4 the middle estimate is 2.7-fold (0.44 log units) above the measured one; the whole stated range lies above it.
By their numbers in this assay, from the lowest: compound 4; then compound 1; then compound 2; then compound 3.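

The ring bearing the amide, constant across compound 1, compound 2 and compound 3, turns out to respond in this assay: fluoro in place of hydrogen on an aromatic carbon, ortho to a large group and meta to a large group, gives a 2.6-fold lower number from compound 1 to compound 4 (0.42 log units; beyond the scatter). A change of a single heavy atom on this ring therefore moves the number downward, whereas both changes of the aryl group on the aromatic nitrogen starting from compound 1 moved it upward. The data shown offer no measured basis for explaining this shift.

As far as these compounds go, whether the shift is specific to fluoro remains open, as a chloro, methoxy or amine group on the same carbon would test. Also open, from the compounds shown here alone, is whether it carries over when the aromatic nitrogen bears 4-methoxyphenyl or 2-chloro-4-(trifluoromethyl)phenyl in place of 4-chlorophenyl.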